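The source may report more compounds than this note shows. Statements on the series, on what has been measured and on what is new or still open speak of the compounds shown alone.

The measured compounds in a functional assay on MCF7 cells (Homo sapiens) for antiproliferative activity, read by MTT assay, with a stated time of 24 h; a lower number here means a stronger inhibitor, a higher number a weaker inhibitor:
compound 1, `Cc1ccc(-c2nn(-c3ccccc3)cc2-c2nc3ccccc3n2S(=O)(=O)c2ccc(F)cc2)cc1`, gives 5270 nM;
compound 2, `Cc1ccc(-c2nn(-c3ccccc3)cc2-c2nc3ccccc3n2S(=O)(=O)c2ccc(Cl)cc2)cc1`, gives 5930 nM;
compound 3, `O=S(=O)(c1ccc(F)cc1)n1c(-c2cn(-c3ccccc3)nc2-c2ccc(C(F)(F)F)cc2)nc2ccccc21`, gives 3120 nM.

Compounds 1 and 2 differ by chloro in place of fluoro on an aromatic carbon, and this change made the step of a 1.1-fold higher number from compound 1 to compound 2 (0.05 log units; within the scatter). Among the measured compounds shown here, compounds 1 and 3 share everything but (trifluoromethyl in place of methyl on an aromatic carbon), a step of a 1.7-fold lower number from compound 1 to compound 3 (0.23 log units; within the scatter), so no compound here is separated from another beyond the scatter.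

Compound 4, `O=S(=O)(c1ccc(Cl)cc1)n1c(-c2cn(-c3ccccc3)nc2-c2ccc(C(F)(F)F)cc2)nc2ccccc21`, is not yet measured. It differs from compound 3 by chloro in place of fluoro on an aromatic carbon, and the place of this change reads the same as for the change from compound 1 to compound 2, so it is the same change. Because the earlier step was a 1.1-fold higher number from compound 1 to compound 2 (0.05 log units; within the scatter), the step from compound 3 to compound 4 is expected to be a 1.1-fold higher number from compound 3 to compound 4 (0.05 log units; within the scatter). Compound 4 is therefore estimated at 3500 nM, between 1800 nM and 7000 nM.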

Compound 4, half-maximal inhibitory concentration: 4320 nM
Estimate against measurement, compound 4: 1.2-fold (0.09 log units) below; low and high end bracket the measured number.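

In this assay, among the compounds shown here, chloro in place of fluoro gave a 1.4-fold higher number from compound 3 to compound 4 (0.14 log units; within the scatter), and this step reads the same as on the earlier core: the same change on two cores in this assay, a 1.1-fold higher number (0.05 log units; within the scatter) from compound 1 to compound 2 and a 1.4-fold higher number (0.14 log units; within the scatter) from compound 3 to compound 4, 1.2-fold (0.09 log units) apart, within the scatter of two such steps Trifluoromethyl in place of methyl gave a 1.4-fold lower number from compound 2 to compound 4 (0.14 log units; within the scatter), and this change also carried across the two cores without a visible difference: the same change on two cores in this assay, a 1.7-fold lower number (0.23 log units; within the scatter) from compound 1 to compound 3 and a 1.4-fold lower number (0.14 log units; within the scatter) from compound 2 to compound 4, 1.2-fold (0.09 log units) apart, within the scatter of two such steps All of these steps lie within the scatter, so the agreement shows only that neither change moved the number measurably on either core, not that either change has a real effect that transfers from core to core.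

The compounds shown vary only these two groups, so it remains open whether an amine, a methoxy group or a carboxylic acid at either place would give a step beyond the scatter. Going by these compounds, whether the unsubstituted phenyl can be replaced also remains open.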